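The source may report more compounds than this note shows. Statements on the series, on what has been measured and on what is new or still open speak of the compounds shown alone.

Going by the values given here, in a functional assay on U-937/GTB cells (Homo sapiens) for cytotoxicity (on this read-out higher numbers stand for weaker inhibition and lower numbers for stronger inhibition), only two compounds have numbers so far. Compound 1 `CC(C)=CCC/C(C)=C/CC/C(C)=C/CC/C(C)=C/C[n+]1cn(C)c2nc[nH]/c(=N\OCc3ccccc3)c21` gives 6790 nM. Compound 2 `CO/N=c1\[nH]cnc2c1[n+](C/C=C(\C)CC/C=C(\C)CC/C=C(\C)CCC=C(C)C)cn2CCC#N` gives 3330 nM, the lower of the two numbers and so the stronger inhibition, with a gap beyond the usual scatter. The next compound, compound 3 `CC(C)=CCC/C(C)=C/CC/C(C)=C/CC/C(C)=C/C[n+]1cn(CCC#N)c2nc[nH]/c(=N\OCc3ccccc3)c21`, is reached from compound 2 by one change: phenyl in place of hydrogen on a saturated chain carbon bound to an oxygen. This turns methoxy into benzyloxy. Among the compounds with values here, no measured pair shows this change on its own, so its size in this assay remains uncertain. The expected result is no step beyond the scatter, with the number perhaps drifting slightly upward. The estimated move is a 1.4-fold higher number from compound 2 to compound 3 (0.13 log units; within the scatter). For compound 3 the estimated value is 4500 nM, with an expected range from 1800 nM to 10000 nM.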

Compound 3, half-maximal inhibitory concentration: 24200 nM
Compound 3: middle estimate off by 5.4-fold (0.73 log units), on the low side; the whole stated range lies below it.
By their numbers in this assay, from the lowest: compound 2; then compound 1; then compound 3.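

In this assay phenyl in place of hydrogen on a saturated chain carbon bound to an oxygen, which turns methoxy into benzyloxy, gives a 7.3-fold higher number from compound 2 to compound 3 (0.86 log units; beyond the scatter) and so weakens inhibition, showing that this place is sensitive to the change. With benzyloxy held fixed, cyanomethyl in place of hydrogen on a saturated chain carbon bound to an aromatic nitrogen gives a 3.6-fold higher number from compound 1 to compound 3 (0.55 log units; beyond the scatter) and also weakens inhibition, so the second place matters as well. Nothing available explains why either change has this effect.

Still open, as far as these compounds go, is whether the aromatic ring itself matters or any larger group would do the same, which an ethoxy or cyclohexylmethoxy group could help separate. A methoxy compound with methyl on that nitrogen would show whether the two steps simply add together.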